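The compounds below may be only part of what the source reports. "The series", "measured", "known", "first", "only" and "open" are said of these compounds alone.

The compounds share one core and differ only in the group on the amide-type nitrogen. Compound 1 `O=C(CSc1nc(Nc2ccccc2)c2ccccc2n1)Nc1cccc([N+](=O)[O-])c1` carries a 3-nitrophenyl there, and in a functional assay on MGC-803 cells (Homo sapiens) for inhibition, read by MTT assay, with a stated time of 72 h (on this read-out lower numbers stand for stronger inhibition and higher numbers for weaker inhibition), compound 1 gives 28100 nM. Compound 2 `O=C(CSc1nc(Nc2ccccc2)c2ccccc2n1)Nc1ccc(Br)cc1` carries a 4-bromophenyl, and in this assay compound 2 gives 19300 nM; the step is a 1.5-fold lower number from compound 1 to compound 2 (0.16 log units; within the scatter). Compound 3 `CCc1ccc(NC(=O)CSc2nc(Nc3ccccc3)c3ccccc3n2)cc1` carries a 4-ethylphenyl. In this assay compound 3 gives only a limit, > 50000 nM. Compound 3 thus stands at the upper edge of the numbers shown, at the limit of > 50000 nM in this assay, at which 1 of the 3 values shown sits. The steps of an at least 1.7-fold higher number from compound 1 to compound 3 (0.25 log units; that floor lies within the scatter) and an at least 2.5-fold higher number from compound 2 to compound 3 (0.41 log units; beyond the scatter) both run toward that limit. Compound 4 `O=C(CSc1nc(Nc2ccccc2)c2ccccc2n1)Nc1ccc(Cl)cc1Cl` differs from compound 3 by 2,4-dichlorophenyl in place of 4-ethylphenyl on an amide-type nitrogen. Within the data shown here, no measured step places two chlorines in exchange for ethyl, but the step of an at least 2.5-fold higher number from compound 2 to compound 3 (0.41 log units; beyond the scatter) shows that a halogen on the aromatic carbon gives a lower number than ethyl, and compound 4 carries halogens where compound 3 carries ethyl. Compound 4 is therefore expected to move away from the limit, with a step estimated as an at least 2.5-fold lower number from compound 3 to compound 4 (0.39 log units; beyond the scatter). The estimate for compound 4 is 20000 nM, with a range from 7000 nM to 50000 nM.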

Compound 4, half-maximal inhibitory concentration: 12300 nM
The estimate for compound 4 lay 1.6-fold (0.21 log units) above the measured number; low and high end bracket the measured number.
By their numbers in this assay, from the lowest: compounds 4, 2 and 1 (each within the scatter of the next, the first and the last beyond it). At a limit, above all of these: compound 3.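

The step of an at least 4.0-fold lower number from compound 3 to compound 4 (0.60 log units; beyond the scatter) shows that 2,4-dichlorophenyl, like 4-bromophenyl, gives a measurable number on this amide-type nitrogen, but its full size stays unread, as the starting value is a limit and not a number: the limit of > 50000 nM in this assay, at which 1 of the 4 values shown sits. The step of a 1.6-fold lower number from compound 2 to compound 4 (0.20 log units; within the scatter) means that in this assay these two halogen-bearing groups cannot be told apart. Among these compounds, the step of a 2.3-fold lower number from compound 1 to compound 4 (0.36 log units; beyond the scatter) separates a halogen-bearing group from 3-nitrophenyl for the first time, which the 4-bromophenyl of compound 2 did not do.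

The compounds shown leave open how a single chlorine, as in 4-chlorophenyl, would read here, and whether the number depends on where the chlorines sit. They also leave open how a methoxy group on this ring, or a longer alkyl chain in place of the ring, would read.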